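This account rests on a few compounds, and the source may have more. Where it says the series, first, only, none or still open, it means among the compounds named here.

Of the compounds shown here, two built on a shared core have so far been tested in a functional assay on A549 cells (Homo sapiens) for inhibition, read by MTT assay, with a stated time of 72 h, tested at 20 uM; on this read-out lower numbers stand for less inhibition and higher numbers for more inhibition at the one concentration tested (going by the name of the read-out). Compound 1 `CN(c1ccc(Oc2ncnc3ccsc23)cc1)c1nccc(N2CCCCC2)n1` gives 65.7% in this assay. Compound 2 `CN(c1ccc(Oc2ncnc3sccc23)cc1)c1nccc(N2CCCC2)n1` gives 55.5% in this assay, the lower of the two numbers, and the gap to compound 1 lies beyond the usual scatter. For the measured compounds named here, compound 1 and compound 2 differ in two places at once, so no single step between them can be read off. Compound 3 `CN(c1ccc(Oc2ncnc3sccc23)cc1)c1nccc(N2CCCCC2)n1` has not yet been measured. It differs from compound 2 in one place: piperidin-1-yl in place of pyrrolidin-1-yl on an aromatic carbon. Going by the values given here, the entering ring is the one that compound 1 carries, while the core is that of compound 2. A moderate step upward is expected, a number 6.5 percentage points higher from compound 2 to compound 3 (within the scatter), since compound 1 with its piperidin-1-yl shows 65.7%. Compound 3 is therefore estimated at 62% in this assay, with a range from 50% to 74%.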

Compound 3, a percentage reported as inhibition, at one concentration (the size of the read-out at that concentration, not a potency): 51.9%
Compound 3: middle estimate off by 10.1 percentage points, on the high side, and the stated range covers the measured number.
By their numbers in this assay, from the lowest: compounds 3 and 2 (each within the scatter of the next); then compound 1.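

In this assay, piperidin-1-yl in place of pyrrolidin-1-yl on this aromatic carbon, next to the ring nitrogen, gives a number 3.6 percentage points lower from compound 2 to compound 3 (within the scatter), so with this core the change of ring size cannot be told apart from the usual scatter. With piperidin-1-yl held fixed, exchanging the group on the oxygen for another of the same atom composition gives a number 13.8 percentage points lower from compound 1 to compound 3 (beyond the scatter), a modest change, so in this pair the arrangement of that group matters more than the ring step does. Nothing available explains either result.

Still open, going by these compounds, is whether morpholin-4-yl or an open-chain amine such as dimethylamino on this carbon would shift the number beyond the scatter. Also open, on these data alone, is whether the effect of the group on the oxygen holds when pyrrolidin-1-yl is present.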